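Dropping the bromo from an indole thiosemicarbazone

This account rests on a few compounds, and the source may have more. Where it says the series, first, only, none or still open, it means among the compounds named here.

The study measures growth inhibition in a functional assay on NCI/ADR-RES cells (Homo sapiens) for inhibition, read by spectrophotometry and sulforhodamine B assay, with a stated time of 48 h; on this read-out higher numbers stand for weaker inhibition of growth and lower numbers for stronger inhibition of growth. Compound 1 `Cc1ccc(N2C(=O)CS/C2=N/N=C/c2c[nH]c3ccccc23)cc1` is recorded in this assay only as a limit, > 100000 nM. Compound 2 `S=C(N/N=C/c1c[nH]c2ccc(Br)cc12)Nc1cccc2ccccc12` carries a bromo on its fused ring and gives 6180 nM in this assay. Among the two results shown, compound 2 is thus the only one with a numerical value, the other being a limit (the limit of > 100000 nM in this assay, at which 1 of the 2 values shown sits). Compound 3 `S=C(N/N=C/c1c[nH]c2ccccc12)Nc1cccc2ccccc12` differs from compound 2 in one place: hydrogen in place of bromo on an aromatic carbon. Within the data shown here, no pair of measured compounds separated by a single change is available, so the size of this step can only be expected, not read off. The replacement of bromo by hydrogen removes one heavy atom and nothing else; a modest weakening in this assay, close to the edge of the usual scatter, seems the likeliest outcome for compound 3. Compound 3 is therefore expected to give about 11000 nM in this assay, most probably between 3500 nM and 35000 nM, corresponding to an estimated step of a 1.8-fold higher number from compound 2 to compound 3 (0.25 log units; within the scatter).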

Compound 3, concentration for 50% growth inhibition: 6480 nM
Compound 3: middle estimate off by 1.7-fold (0.23 log units), on the high side, within the range that was stated.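

Among these compounds, this is the first pair that differs in one place only, and the exchange of bromo for hydrogen gives a 1.0-fold higher number from compound 2 to compound 3 (0.02 log units; within the scatter) in this assay as its single readable step. On an aromatic carbon of this six-membered ring, meta to a fused ring and para to a fused ring, the read-out therefore does not separate bromo from hydrogen in this pair, so the growth inhibition seen for compound 2 does not depend on the bromo, and compound 3 keeps it without that atom. Nothing measured here offers an explanation for this result.

Whether the same place would tolerate a larger or charged group, such as a methoxy, an amine or a carboxylic acid, remains open, since bromo and hydrogen are the only two substituents shown there and one pair cannot establish a trend. Compound 1 is recorded only as a limit, > 100000 nM, and it differs from compound 3 in more than one place, so the share of each of its differences in that result cannot be read.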